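The compounds below may be only part of what the source reports. "The series", "measured", "known", "first", "only" and "open" are said of these compounds alone.

In a functional assay on HT cells (Homo sapiens) for antiproliferative activity, read by fluorescence, with a stated time of 72 h (on this read-out lower numbers stand for stronger inhibition of growth and higher numbers for weaker inhibition of growth), the measured compounds are:

compound 1 `CC(C)c1n[nH]c2c(NCc3ccc(-c4ccccn4)cc3)nc(SCCC(N)=O)nc12`: 120 nM
compound 2 `CC(C)c1n[nH]c2c(NCc3ccc(-c4ccccn4)cc3)nc(SCCCN(C)C)nc12`: 105 nM

Compound 2 has the lower of the two numbers, but its gap to compound 1 is within the scatter. Compound 3 `C=CCSc1nc(NCc2ccc(-c3ccccn3)cc2)c2[nH]nc(C(C)C)c2n1` differs from compound 2 in the chain on the sulfur: vinyl in place of 2-(dimethylamino)ethyl on a saturated chain carbon bound to a sulfur. Within the data shown here, the only step bearing on this position, a 1.1-fold lower number from compound 1 to compound 2 (0.06 log units; within the scatter), exchanged one end group for another without moving the number; compound 3 instead shortens the chain and drops the acceptor, so no measured step covers this. The estimated step of a 1.7-fold higher number from compound 2 to compound 3 (0.23 log units; within the scatter) is therefore small and uncertain, and for compound 3 the expected value is 180 nM, within 60 nM to 550 nM.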

Compound 3, concentration for 50% growth inhibition: 1010 nM
Estimate against measurement, compound 3: 5.6-fold (0.75 log units) below, and the stated range ends below it.
By their numbers in this assay, from the lowest: compounds 2 and 1 (each within the scatter of the next); then compound 3.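

Unlike the swap of end groups between compound 1 and compound 2, this change at the chain on the sulfur moves the number in this assay beyond the scatter: vinyl in place of 2-(dimethylamino)ethyl gives weaker growth inhibition (a 9.6-fold higher number from compound 2 to compound 3 (0.98 log units; beyond the scatter)), and vinyl in place of carbamoylmethyl does the same (an 8.4-fold higher number from compound 1 to compound 3 (0.93 log units; beyond the scatter)). Two different end groups thus give values within the scatter of each other, while the allyl chain stands apart. Nothing at hand offers a reason for this gap.

Vinyl differs from both earlier groups in chain length and in its end, so these compounds cannot separate the two. A short chain ending in an amine, or a longer plain carbon chain, would be needed to tell them apart.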